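The compounds below may be only part of what the source reports. "The series", "measured", "known", "first", "only" and "open" are said of these compounds alone.

Measured compounds:
Compound 1, `COc1ccc(C(=O)/C=C/c2ccc(Br)cc2)c2c1C=CC(C)(C)O2`: in a functional assay on HepG2 cells (Homo sapiens) for antiproliferative activity, read by MTT assay, with a stated time of 24 h (a higher number here means a weaker inhibitor, a lower number a stronger inhibitor), compound 1 gives > 10000 nM, a limit of the assay.
Compound 2, `COc1ccc(C(=O)/C=C/c2ccc(N(c3ccccc3)c3ccccc3)cc2)c2c1C=CC(C)(C)O2`: in this assay compound 2 gives > 10000 nM, also a limit of the assay.

Within the data shown here, compound 1 therefore stands on no number at all: its value in this assay is a limit, and the only other value shown is a limit as well, so that both values shown sit at the limit of > 10000 nM in this assay, at which 2 of the 2 values shown sit. Among the measured compounds shown here, no step between two measured compounds can be drawn from such a pair, and nothing among the measured values sets compound 1 apart from compound 2.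

The compound that follows is compound 3, `COc1ccc(C(=O)/C=C/c2ccc(-n3ccnc3)cc2)c2c1C=CC(C)(C)O2`. It differs from compound 1 in one place: 1H-imidazol-1-yl in place of bromo on an aromatic carbon, para to a large group.

For the measured compounds named here, since compound 1 sits at the limit of > 10000 nM in this assay, at which 2 of the 2 values shown sit, there is no measured step on which to build, and the expected step from compound 1 to compound 3 is a step that the limit leaves unreadable from compound 1 to compound 3, none beyond the scatter. Compound 3 is accordingly estimated at 12000 nM, with a range from 4000 nM to 40000 nM, and it may well again return only a limit.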

Compound 3, half-maximal inhibitory concentration: > 10000 nM
Compound 3: a limit, no number; the forecaster's own chance of this, stated with the estimate: 75%; the middle value is on the limit's open side.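

In this assay compound 3 gives > 10000 nM, a limit of the assay. No step from compound 1 to compound 3 can be read, since the value of each is only a limit: the limit of > 10000 nM in this assay, at which 3 of the 3 values shown sit.

The compounds shown leave open whether any group at this place on the shared core gives a measurable value in this assay.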